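The source may report more compounds than this note shows. Statements on the series, on what has been measured and on what is new or still open speak of the compounds shown alone.

The three measured compounds share the core of compound 1 `O=C(Nc1ccccc1)C1CCN(C/C=C/c2ccccc2)CC1` and differ in one group. In a functional assay on MGC-803 cells (Homo sapiens) for inhibition, read by MTT assay, with a stated time of 72 h (on this read-out lower numbers stand for stronger inhibition and higher numbers for weaker inhibition), compound 1 gives 57900 nM. Compound 2 `CCc1ccc(NC(=O)C2CCN(C/C=C/c3ccccc3)CC2)cc1`, which carries an ethyl, gives 11600 nM, and compound 3 `O=C(Nc1cccc(C(F)(F)F)c1)C1CCN(C/C=C/c2ccccc2)CC1`, which carries a trifluoromethyl, gives 9590 nM. These last two values lie within the scatter of each other, so compound 3 stands level with compound 2, and both stand clearly apart from compound 1.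

Compound 4 `O=C(Nc1cccc(F)c1)C1CCN(C/C=C/c2ccccc2)CC1` changes compound 3 at a single place: fluoro in place of trifluoromethyl on an aromatic carbon. In words, this is fluoro in place of trifluoromethyl on an aromatic carbon. For the measured compounds named here, two measured steps bear on this change, a 5.0-fold lower number from compound 1 to compound 2 (0.70 log units; beyond the scatter) for ethyl in place of hydrogen and a 6.0-fold lower number from compound 1 to compound 3 (0.78 log units; beyond the scatter) for trifluoromethyl in place of hydrogen. Both are modest but beyond the scatter. Going by the values given here, no fluoro compound has been measured on this core, so the expectation rests on those steps alone. Taking a 6.0-fold lower number from compound 1 to compound 3 (0.78 log units; beyond the scatter) as the available span, compound 4 is expected to give back part of that step and fall between compound 3 and compound 1. In this assay, the expected result is a modest move to a higher number, a 2.1-fold higher number from compound 3 to compound 4 (0.32 log units; beyond the scatter). For compound 4, the estimated value is 20000 nM, with an expected range of 8000 nM to 45000 nM.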

Compound 4, half-maximal inhibitory concentration: 23300 nM
Estimate against measurement, compound 4: 1.2-fold (0.07 log units) below; the measured number falls inside the stated range.
By their numbers in this assay, from the lowest: compounds 3, 2 and 4 (each within the scatter of the next, the first and the last beyond it); then compound 1.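

In this assay, even a single fluorine atom on this aromatic carbon has a measurable effect, as the step of a 2.5-fold lower number from compound 1 to compound 4 (0.40 log units; beyond the scatter) shows, and that step lies beyond the scatter. The group that sits there also matters, not merely whether the position is filled: replacing trifluoromethyl, with 4 heavy atoms, by fluoro, with 1 heavy atom, at the same place gives a 2.4-fold higher number from compound 3 to compound 4 (0.39 log units; beyond the scatter), so fluoro keeps only part of the gain seen with trifluoromethyl. The comparison with the ethyl compound gives a 2.0-fold higher number from compound 2 to compound 4 (0.30 log units; within the scatter), which lies within the scatter, so these numbers do not separate the 3-fluorophenyl and 4-ethylphenyl groups on the amide-type nitrogen, even though the two compounds differ in both the group and its place on the ring.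

No measurement shown gives a reason for the size of any of these steps. From the compounds shown here alone, it remains open whether chloro, methoxy, an amine, a carboxylic acid or a longer chain at this same place would bring the number lower than in compound 3, or would lose the gain over compound 1 altogether.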